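Trifluoromethoxy in Place of Iodo on the Phenoxy Group

The source may report more compounds than this note shows. Statements on the series, on what has been measured and on what is new or still open speak of the compounds shown alone.

Compound 1, `Cc1nn(C)c(Oc2ccc(F)c(F)c2)c1/C=N\CCCCCCOc1cc2oc(=O)cc(C)c2cc1Cl`: > 25000 nM
Compound 2, `Cc1nn(C)c(Oc2ccccc2Br)c1/C=N\CCCCCCOc1cc2oc(=O)cc(C)c2cc1Cl`: 24200 nM
Compound 3, `Cc1nn(C)c(Oc2ccc(I)cc2)c1/C=N\CCCCCCOc1cc2oc(=O)cc(C)c2cc1Cl`: 14200 nM

The three measured compounds share one core and differ only in the aryl group on an oxygen on an aromatic ring. In a functional assay on HepG2 cells (Homo sapiens) for antiproliferative activity, read by MTT assay, with a stated time of 72 h (a lower number here means a stronger inhibitor, a higher number a weaker inhibitor), compound 1 gives > 25000 nM, which is a limit of the assay and not a number: the limit of > 25000 nM in this assay, at which 1 of the 3 values shown sits. Compound 2 gives 24200 nM in this assay. Compound 3 gives 14200 nM and holds the lowest of the two numbers, with compound 2 nearest: a 1.7-fold lower number from compound 2 to compound 3 (0.23 log units; within the scatter). The remaining steps, an at least 1.0-fold lower number from compound 1 to compound 2 (0.01 log units; that floor lies within the scatter) and an at least 1.7-fold lower number from compound 1 to compound 3 (0.24 log units; that floor lies within the scatter), rest on that limit and are floors only.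

Compound 4, `Cc1nn(C)c(Oc2ccc(OC(F)(F)F)cc2)c1/C=N\CCCCCCOc1cc2oc(=O)cc(C)c2cc1Cl`, differs from compound 3 by trifluoromethoxy in place of iodo on an aromatic carbon. Among the compounds with values here, no measured step exchanges just that group; the measured steps swap whole aryl groups and none of them leaves the scatter. Compound 4 is therefore expected to stay close to compound 3, with an estimated step of a 1.3-fold higher number from compound 3 to compound 4 (0.10 log units; within the scatter). Compound 4 is estimated at 18000 nM, between 8000 nM and 40000 nM.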

Compound 4, half-maximal inhibitory concentration: 8160 nM
Beside the measured number, compound 4's estimate is 2.2-fold (0.34 log units) above it; low and high end bracket the measured number.
By their numbers in this assay, from the lowest: compounds 4, 3 and 2 (each within the scatter of the next, the first and the last beyond it). At a limit, above all of these: compound 1.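

In this assay, within the data shown here, the single exchange of iodo for trifluoromethoxy on this aromatic carbon gives a 1.7-fold lower number from compound 3 to compound 4 (0.24 log units; within the scatter), so this change alone does not leave the scatter. Among these compounds, the aryl group on this oxygen can still move the number beyond the scatter, which no earlier step between two measured numbers showed: 4-(trifluoromethoxy)phenyl in place of 2-bromophenyl gives a 3.0-fold lower number from compound 2 to compound 4 (0.47 log units; beyond the scatter). In place of 3,4-difluorophenyl the same group gives an at least 3.0-fold lower number from compound 1 to compound 4 (0.48 log units; beyond the scatter), which is a floor only, since compound 1 stands at a limit: the limit of > 25000 nM in this assay, at which 1 of the 4 values shown sits.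

The compounds shown leave open how an amine or a carboxylic acid on this aromatic carbon would read in this assay. They also leave open whether the place of the substituent or the group itself accounts for the gap, as compound 2 and compound 4 differ in both.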